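This account rests on a few compounds, and the source may have more. Where it says the series, first, only, none or still open, it means among the compounds named here.

Among the compounds with values here, in an assay on isolated protein for inhibition of Aromatase (Homo sapiens), read by fluorescence, with a stated time of 30 min (on this read-out higher numbers stand for weaker inhibition and lower numbers for stronger inhibition), compound 1 `N#CC/C(=C(/c1ccc(O)cc1)c1ccc(OCCN)cc1)c1ccccc1` gives 48.9 nM, the lowest of the two numbers measured so far. Within the data shown here, the only other measured compound, compound 2 `NCCOc1ccc(/C(=C2\CCc3ccccc32)c2ccc(O)cc2)cc1`, gives 493 nM in this assay, a gap from compound 1 that lies beyond the usual scatter of repeated measurements. Compound 3 `CCC/C(=C(/c1ccc(O)cc1)c1ccc(OCCN)cc1)c1ccccc1` has not yet been measured. It differs from compound 1 in one place: ethyl in place of cyano on a saturated chain carbon bound to a double-bonded chain carbon. Among the measured compounds shown here, no pair of measured compounds isolates this change, so the expectation can rest only on the number for compound 1 and the size of the change itself. In this assay the expected step is a 3.1-fold higher number from compound 1 to compound 3 (0.49 log units; beyond the scatter), a move toward weaker inhibition that is estimated to reach a little beyond the scatter. Compound 3 is therefore expected to give 150 nM in this assay, with a plausible range from 50 nM to 500 nM.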

Compound 3, half-maximal inhibitory concentration: 261 nM
Compound 3: the middle estimate sits 1.7-fold (0.24 log units) below what was measured, within the range that was stated.
By their numbers in this assay, from the lowest: compound 1; then compounds 3 and 2 (each within the scatter of the next).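

In this assay, ethyl in place of cyano on this saturated chain carbon gives a 5.3-fold higher number from compound 1 to compound 3 (0.73 log units; beyond the scatter), a step toward weaker inhibition. This shows that the read-out responds to the group at this place, which the earlier comparison of compound 1 and compound 2 could not isolate. Cyano and ethyl each hold 2 heavy atoms, so the step arises without a change in that count, although the cyano brings a triple bond and a hydrogen-bond acceptor that the ethyl lacks, and nothing available explains the direction or size of the step.

As far as these compounds go, how an amine, a carboxylic acid or a longer chain would read at this place remains open. Within the data shown here, with only this one pair, it is also open whether the same swap would give a similar step on a different core.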